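The source may hold more compounds than are shown below. What is called first, only, known or untested is meant among the compounds shown, and "the series" means these compounds.

In a functional assay on A549 cells (Homo sapiens) for inhibition, read by MTT assay, with a stated time of 48 h (a higher number here means a weaker inhibitor, a lower number a stronger inhibitor), compound 1 `COc1ccc(C(c2c[nH]c3ccc(Br)cc23)c2c[nH]c3ccc(Br)cc23)cc1` gives 10000 nM. Compound 2 `O=[N+]([O-])c1ccc2[nH]cc(C(c3ccc(Cl)cc3)c3c[nH]c4ccc([N+](=O)[O-])cc34)c2c1` gives > 100000 nM, which is a limit of the assay and not a number. Compound 3 `O=[N+]([O-])c1ccc(C(c2c[nH]c3ccc([N+](=O)[O-])cc23)c2c[nH]c3ccc([N+](=O)[O-])cc23)cc1` swaps 4-chlorophenyl for 4-nitrophenyl, putting nitro in place of chloro on an aromatic carbon. Among the measured compounds shown here, no measured pair of compounds differs in only one place, so nothing shows directly what such a change does. No shift beyond the usual scatter is expected, in either direction, and the estimated change is a number no higher from compound 2 to compound 3 (the limit leaves the size open). Compound 3 is expected to give about 100000 nM, with an estimated range of 30000 nM to 300000 nM.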

Compound 3, half-maximal inhibitory concentration: > 100000 nM
Compound 3 ended at the assay's limit; the forecaster's own chance of this, stated with the estimate: 65%; the middle value lies on the limit itself.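

Among the compounds shown here, compound 2 and compound 3 both end at a limit of the assay, not at a number, and no step between them can be read. In this assay, going by these compounds, the effect of nitro in place of chloro on an aromatic carbon stays open.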